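Swapping methyl for cyclopropyl on a carbonyl carbon

A few compounds are considered here, and "the series" means these few. Any claim that something is new, unique, unknown or untested is made for them only; others in the source may bear on it.

compound 1 `Cc1ccc(-c2ccc(Cl)cc2)n1-c1ccc(S(N)(=O)=O)cc1`: 6100 nM
compound 2 `CC(=O)c1cc(-c2ccc(S(N)(=O)=O)cc2)n(-c2ccc(Cl)cc2)n1`: 86800 nM

Both numbers come from a physicochemical assay for solubility, read by HPLC, in phosphate buffer, measured as kinetic solubility, at pH 7.4; on this read-out higher numbers stand for higher solubility and lower numbers for lower solubility. Compound 2 stands highest of the two. Compound 1 stands lower, and that gap lies beyond the usual scatter of repeated measurements.

The next compound to be measured is compound 3 `NS(=O)(=O)c1ccc(-c2cc(C(=O)C3CC3)nn2-c2ccc(Cl)cc2)cc1`. It departs from compound 2 in one place: cyclopropyl in place of methyl on a carbonyl carbon. In words, this is cyclopropyl in place of methyl on a carbonyl carbon, or acetyl to cyclopropylcarbonyl.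

Going by the values given here, no two measured compounds differ in only one place, so there is no measured step to serve as a guide, and any forecast here is uncertain. The starting point is compound 2 at 86800 nM. From there, a moderate downward step in this assay, slightly beyond the scatter, is expected, although no change at all remains possible. The expected step is a 2.5-fold lower number from compound 2 to compound 3 (0.39 log units; beyond the scatter). The estimated value for compound 3 is 35000 nM, with an expected range from 10000 nM to 90000 nM.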

Compound 3, solubility: 25600 nM
For compound 3 the middle estimate is 1.4-fold (0.14 log units) above the measured one, within the range that was stated.
By their numbers in this assay, from the lowest: compound 1; then compound 3; then compound 2.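

The series now holds its first pair of compounds that differ in only one place, so this assay can be read for a single change: on a carbonyl carbon whose other neighbour is an aromatic carbon, cyclopropyl in place of methyl gives a 3.4-fold lower number from compound 2 to compound 3 (0.53 log units; beyond the scatter). The step is modest but lies beyond the usual scatter, which shows that the number at this position does respond to the group on the carbonyl carbon, and that compound 3 still reads 25600 nM with the three-membered ring in place. The data shown offer no measurement that explains why the number moves in this direction.

A single step cannot say whether the ring itself matters or whether any group larger than methyl would produce a similar step, and an ethyl or an isopropyl on the same carbonyl carbon would help to separate those two readings. On these data alone, it also remains open how this position would respond to a group carrying nitrogen or oxygen, such as an amine or a methoxy group on that carbon.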